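The source may report more compounds than this note shows. Statements on the series, on what has been measured and on what is new or still open speak of the compounds shown alone.

Compound 1, `CC(/C=N/Nc1ccc([N+](=O)[O-])cc1)=N\NC(=O)c1ccc(O)cc1`, in a functional assay on cells (Splenocyte, Mus musculus, strain BALB/c) for inhibition, read by scintillation counting and thymidine incorporation, with a stated time of 72 h; on this read-out higher numbers stand for weaker inhibition and lower numbers for stronger inhibition: 1510 nM
Compound 2, `CC(/C=N/Nc1ccc([N+](=O)[O-])cc1)=N\NC(=O)c1ccccc1C`, in this assay: 6000 nM

Both measured compounds share the same core and differ only in the ring attached to the carbonyl carbon. Compound 2 has the highest number of the two. Its nearest neighbour is compound 1, and the step of a 4.0-fold higher number from compound 1 to compound 2 (0.60 log units; beyond the scatter) lies beyond the usual scatter, so compound 2 is the weaker inhibitor of the pair.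

Compound 3, `CC(/C=N/Nc1ccc([N+](=O)[O-])cc1)=N\NC(=O)c1ccc(N(C)C)cc1`, has not been measured. It differs from compound 2 in one place: 4-(dimethylamino)phenyl in place of 2-methylphenyl on a carbonyl carbon. Among the compounds with values here, the only measured step that bears on this change is a 4.0-fold higher number from compound 1 to compound 2 (0.60 log units; beyond the scatter), in which a 4-hydroxyphenyl gave way to a 2-methylphenyl and the number rose. Compound 3 moves back to a 4-substituted ring, 4-(dimethylamino)phenyl, which brings one hydrogen-bond acceptor, though no donor as the hydroxyl did. A lower number than compound 2 is therefore expected, probably not reaching all the way down to compound 1.

Compound 3 is expected to give about 2500 nM, with a range from 800 nM to 8000 nM. The expected step is a 2.4-fold lower number from compound 2 to compound 3 (0.38 log units; beyond the scatter), toward stronger inhibition.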

Compound 3, half-maximal inhibitory concentration: > 12000 nM
Compound 3 was reported as a limit; the forecaster's own chance of this, stated with the estimate: 5%; middle value at least 4.8-fold (0.68 log units) away from the limit.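

In this assay, compound 3 is reported only as a limit of the assay, not as a number: the limit of > 12000 nM in this assay, at which 1 of the 3 values shown sits. Even so, the comparison with compound 1 is informative: with dimethylamino in place of hydroxy on an aromatic carbon, the result is an at least 7.9-fold higher number from compound 1 to compound 3 (0.90 log units; beyond the scatter), so 4-(dimethylamino)phenyl does not preserve the inhibition seen with 4-hydroxyphenyl, and a return to a 4-substituted ring is not enough on its own. The comparison with compound 2 says less: the result is an at least 2.0-fold higher number from compound 2 to compound 3 (0.30 log units; that floor lies within the scatter), and because this is only a floor that lies within the scatter, it does not establish an order between these two compounds, although it gives no sign that 4-(dimethylamino)phenyl improves on 2-methylphenyl.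

The three compounds cannot show whether the hydroxy group of compound 1 matters for its hydrogen-bond donor, since dimethylamino differs from it in more than that one feature. On these data alone, a methoxy group or an unsubstituted amine in place of that hydroxy on the aromatic carbon would help separate these possibilities, and how far compound 3 truly lies from compound 2 remains unknown.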